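The source may hold more compounds than are shown below. What is called first, only, known or untested is meant among the compounds shown, and "the series" means these compounds.

Compound 1 `COC(=O)CC1c2ccccc2N=C(N2CCOCC2)N1C(C)C` and compound 2 `COC(=O)CC1c2ccccc2N=C(N2CCN(C)CC2)N1C(C)C` share a core, and in a functional assay on cells (Oocyte) for inhibition of Voltage-dependent T-type calcium channel subunit alpha-1H (Homo sapiens), tested at 100 uM (a higher number here means more inhibition at the concentration tested (going by the name of the read-out), a lower number less inhibition), compound 1 gives about 0% while compound 2 gives about 0%. The change between them is 4-methylpiperazin-1-yl in place of morpholin-4-yl on a carbon with a double bond to nitrogen, and the step it made was no change at the digits printed from compound 1 to compound 2 (within the scatter). Compound 3 `O=C(CC1c2ccccc2N=C(N2CCOCC2)N1c1ccccc1)OCc1ccccc1` gives 20.9% in this assay, the highest of the three numbers; the difference between the core of compound 3 and that of compound 1 is not broken down here. Compound 4 `CN1CCN(C2=Nc3ccccc3C(CC(=O)OCc3ccccc3)N2c2ccccc2)CC1` carries the same kind of change, (4-methylpiperazin-1-yl in place of morpholin-4-yl on a carbon with a double bond to nitrogen), though here the ring atom beside the changed carbon bears a phenyl group rather than an isopropyl group and the other substituent is a (benzyloxycarbonyl)methyl group rather than a (methoxycarbonyl)methyl group. Since compound 1 to compound 2 showed no change at the digits printed from compound 1 to compound 2 (within the scatter), compound 4 is expected to move by about a number 2.9 percentage points lower from compound 3 to compound 4 (within the scatter) in this assay, an estimate of 18%, expected between 4% and 32%.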

Compound 4, a percentage reported as inhibition, at one concentration (the size of the read-out at that concentration, not a potency): 32.7%
Estimate against measurement, compound 4: 14.7 percentage points below; the measured number lies above the stated range.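

On the core of compound 3, 4-methylpiperazin-1-yl in place of morpholin-4-yl gives a number 11.8 percentage points higher from compound 3 to compound 4 (beyond the scatter) in this assay. Set beside the same change on the core of compound 1, the two steps cannot be told apart, so the change carries across these two cores without a resolvable difference: the same change on two cores in this assay, no change at the digits printed (within the scatter) from compound 1 to compound 2 and a number 11.8 percentage points higher (beyond the scatter) from compound 3 to compound 4, 11.8 percentage points apart, within the scatter of two such steps. This does not show that the step has the same size on both cores, and two pairs say nothing about any further core.

The compounds shown leave open how a piperidin-1-yl group or a piperazine with a free ring amine would read on a carbon with a double bond to nitrogen. They also leave open what the change does when a phenyl group is paired with a (methoxycarbonyl)methyl group.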